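The compounds below may be only part of what the source reports. "The series", "measured", "known", "first", "only" and "open" are said of these compounds alone.

In a functional assay on BGC-823 cells (Homo sapiens) for cytotoxicity, read by MTT assay, with a stated time of 4 days (on this read-out higher numbers stand for weaker inhibition and lower numbers for stronger inhibition), compound 1, `COc1cc(C(=O)O[C@@H]2C[C@](C)(O)[C@H]3[C@H](O[C@@H]4O[C@H](CO)[C@@H](O)[C@H](O)[C@H]4O)OC=C[C@H]32)ccc1O[C@@H]1O[C@H](CO)[C@@H](O)[C@H](O)[C@H]1O`, gives > 10000 nM, which is a limit of the assay rather than a measured number. Compound 2, `CC(/C=C/[C@@]1(O)C(C)(C)CCC[C@@]1(C)O)=C\C(=O)O[C@@H]1C[C@](C)(O)[C@H]2[C@H](O[C@@H]3O[C@H](CO)[C@@H](O)[C@H](O)[C@H]3O)OC=C[C@H]21`, gives > 10000 nM in this assay, again a limit. Compound 3, `CC(/C=C/[C@@]1(O)C(C)(C)C[C@H](O)C[C@@]1(C)O)=C\C(=O)O[C@@H]1C[C@](C)(O)[C@H]2[C@H](O[C@@H]3O[C@H](CO)[C@@H](O)[C@H](O)[C@H]3O)OC=C[C@H]21`, gives > 10000 nM in this assay, also a limit. Compound 3 therefore stands exactly where every measured compound here stands: at the limit of > 10000 nM in this assay, at which 3 of the 3 values shown sit. Within the data shown here, the only step between two compounds that differ in one place is a step that the two limits leave unreadable from compound 2 to compound 3, a hydroxy in place of hydrogen on a saturated ring carbon. Its size cannot be read because the limit of > 10000 nM in this assay, at which 3 of the 3 values shown sit, covers both of its ends.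

Compound 4, `CC(/C=C/[C@@]1(O)C(C)(C)CC[C@@H](O)[C@@]1(C)O)=C\C(=O)O[C@@H]1C[C@](C)(O)[C@H]2[C@H](O[C@@H]3O[C@H](CO)[C@@H](O)[C@H](O)[C@H]3O)OC=C[C@H]21`, has not yet been measured. It differs from compound 3 by 1,2,3-trihydroxy-2,6,6-trimethylcyclohexyl in place of 1,2,4-trihydroxy-2,6,6-trimethylcyclohexyl on a double-bonded chain carbon bound to a double-bonded chain carbon; the two share the same atoms, joined differently. Among the measured compounds shown here, no measured step shows what such a shift of a hydroxy on this ring does, and the one step that touches this ring is itself unreadable. With three limits and no readable step, nothing points to a change beyond the scatter in either direction. Compound 4 is expected to give about 15000 nM in this assay, most likely reported only as a limit again, within a range from 5000 nM to 50000 nM. The step this estimate means, a step that the limit leaves unreadable from compound 3 to compound 4, is expected to stay within the scatter.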

Compound 4, half-maximal inhibitory concentration: > 10000 nM
Compound 4: no number, only a limit; the forecaster's own chance of this, stated with the estimate: 85%; the middle value is on the limit's open side.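

Compound 4 also gives only a limit, so neither its step from compound 3 nor its step from compound 2 can be read: the limit of > 10000 nM in this assay, at which 4 of the 4 values shown sit.

The compounds shown leave open how strongly any of them acts in this assay and whether 1,2,3-trihydroxy-2,6,6-trimethylcyclohexyl and 1,2,4-trihydroxy-2,6,6-trimethylcyclohexyl differ there at all.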